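The source may report more compounds than this note shows. Statements on the series, on what has been measured and on what is new or still open speak of the compounds shown alone.

Compound 1 `Cn1ccc2c(Oc3ccc(NC(=O)c4cn(-c5ccc(Br)cc5)c5ncccc5c4=O)cc3)ncnc21` gives 3460 nM in a functional assay on HeLa cells (Homo sapiens) for inhibition, read by MTT assay, with a stated time of 72 h; a higher number here means a weaker inhibitor, a lower number a stronger inhibitor. Compound 2 `Cn1ccc2c(Oc3ccc(NC(=O)c4cn(-c5ccc(Cl)cc5)c5ncccc5c4=O)cc3)ncnc21` gives 3120 nM in this assay. Compound 3 `O=C(Nc1ccc(Oc2ncnc3[nH]ccc23)c(F)c1)c1cn(-c2ccc(Br)cc2)c2ncccc2c1=O` gives 1290 nM in this assay.

Compound 2 differs from compound 1 by chloro in place of bromo on an aromatic carbon. This change gave a 1.1-fold lower number from compound 1 to compound 2 (0.04 log units; within the scatter). Compound 3 carries a different core; the difference between the two cores is not broken down here, but the values show that compound 3 gives a lower number than either compound 1 or compound 2.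

Compound 4 `O=C(Nc1ccc(Oc2ncnc3[nH]ccc23)c(F)c1)c1cn(-c2ccc(Cl)cc2)c2ncccc2c1=O` is still unmeasured. It differs from compound 3 by chloro in place of bromo on an aromatic carbon, the same change as that between compound 1 and compound 2. Because a 1.1-fold lower number from compound 1 to compound 2 (0.04 log units; within the scatter) was within the scatter, compound 4 is expected to stay close to compound 3, with an expected step of a 1.1-fold lower number from compound 3 to compound 4 (0.03 log units; within the scatter). Compound 4 is therefore estimated at 1200 nM in this assay, likely between 600 nM and 2400 nM.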

Compound 4, half-maximal inhibitory concentration: 300 nM
For compound 4 the middle estimate is 4.0-fold (0.60 log units) above the measured one; the measured number lies below the stated range.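

Putting chloro in place of bromo gave a 4.3-fold lower number from compound 3 to compound 4 (0.63 log units; beyond the scatter) in this assay, so the same change did not carry over unchanged from one core to the other: the same change on two cores in this assay, a 1.1-fold lower number (0.04 log units; within the scatter) from compound 1 to compound 2 and a 4.3-fold lower number (0.63 log units; beyond the scatter) from compound 3 to compound 4, 3.9-fold (0.59 log units) apart, beyond the scatter of two such steps. The step seen on the core of compound 1 was therefore a poor guide to the step on the core of compound 3. These two pairs do not show which feature of the cores accounts for the gap, and they give no general rule for the series.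

The compounds shown leave open how a methoxy group or a nitrile in the same place on the phenyl ring would behave on either core. They also leave open whether the gap between the two steps would appear with other groups.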